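This account rests on a few compounds, and the source may have more. Where it says the series, first, only, none or still open, it means among the compounds named here.

In a functional assay on MKN-74 cells (Homo sapiens) for antiproliferative activity, with a stated time of 24 h (on this read-out lower numbers stand for stronger inhibition and higher numbers for weaker inhibition), compound 1 `NC(=O)c1c(NC(=O)c2ccccc2Cl)sc2c1CCN(Cc1ccc(Cl)cc1)C2` gives 18700 nM. Compound 2 `NC(=O)c1c(NC(=O)c2ccc(C(F)(F)F)cc2)sc2c1CCN(Cc1ccc(Cl)cc1)C2` differs from it in one place, and the step of an at least 2.6-fold higher number from compound 1 to compound 2 (0.42 log units; beyond the scatter) ends at a limit. For compound 2 this assay reports only > 50000 nM, which is a limit of the measurement and not a number. Among the values shown, compound 2 is the one sitting at the limit of > 50000 nM in this assay, at which 1 of the 3 values shown sits. Compound 3 `CSc1ccccc1C(=O)Nc1sc2c(c1C(N)=O)CCN(C(=S)Nc1ccccc1Cl)C2` gives 6550 nM in this assay; it differs from compound 1 in two places, so its value stands on its own. Compound 4 `NC(=O)c1c(NC(=O)c2ccc(C(F)(F)F)cc2)sc2c1CCN(C(=O)Nc1ccccc1Cl)C2` is not yet measured; it arises from compound 2 by (2-chlorophenyl)carbamoyl in place of 4-chlorobenzyl on an amine nitrogen in a ring. Going by the values given here, no measured step covers this change, since the single step of an at least 2.6-fold higher number from compound 1 to compound 2 (0.42 log units; beyond the scatter) concerns the group on the carbonyl carbon, which compound 4 shares with compound 2. The expected step of an at least 1.2-fold lower number from compound 2 to compound 4 (0.09 log units; that floor lies within the scatter) is thus uncertain, and a number near the starting limit is anticipated. In this assay compound 4 is estimated at 40000 nM, within a range of 10000 nM to 100000 nM.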

Compound 4, half-maximal inhibitory concentration: 43900 nM
The estimate for compound 4 lay 1.1-fold (0.04 log units) below the measured number; the range from low to high includes it.
By their numbers in this assay, from the lowest: compound 3; then compound 1; then compound 4. At a limit, above all of these: compound 2.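

At the amine nitrogen in the ring, replacing 4-chlorobenzyl with (2-chlorophenyl)carbamoyl gives, in this assay, an at least 1.1-fold lower number from compound 2 to compound 4 (0.05 log units; that floor lies within the scatter), the first one-place step shown at this position. The starting value of that step, for compound 2, is a limit of the assay and not a number: the limit of > 50000 nM in this assay, at which 1 of the 4 values shown sits.
Going by these compounds, with 4-(trifluoromethyl)phenyl on the carbonyl carbon, compound 4 does give a real number, 43900 nM, but the true size of this change remains unknown and could be small or large.

On these data alone, it remains open whether the carbonyl of the entering group, its added amide hydrogen, or the placement of chlorine on the aromatic ring matters most. A methyl or acetyl group on this nitrogen would test how much the aromatic ring itself contributes.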